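A few compounds are considered here, and "the series" means these few. Any claim that something is new, unique, unknown or untested is made for them only; others in the source may bear on it.

In a functional assay on MDA-MB-231 cells (Homo sapiens) for cytotoxicity, read by MTT assay, with a stated time of 72 h (a higher number here means a weaker inhibitor, a lower number a stronger inhibitor), three compounds have been measured:

- Compound 1 `Nc1ccccc1NC(=O)c1ccc(CNC(=O)c2cc3cccnc3[nH]2)cc1`: > 100000 nM
- Compound 2 `Nc1ccccc1NC(=O)c1ccc(NC(=S)NCc2ccccc2F)cc1`: > 100000 nM
- Compound 3 `Nc1ccccc1NC(=O)c1ccc(Cn2cc(-c3ccc(NC(=O)NCc4cccnc4)cc3)nn2)cc1`: > 100000 nM

Each entry is a limit of the assay and not a number, so the three cannot be ranked. The set sits together: the limit of > 100000 nM in this assay, at which 3 of the 3 values shown sit. Compound 2 has only a limit, > 100000 nM.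

Compound 4 `Nc1ccccc1NC(=O)c1ccc(NC(=S)NCc2cncc(Br)c2)cc1`, not yet measured, carries 5-bromopyridin-3-yl in place of 2-fluorophenyl on a saturated chain carbon bound to an amide-type nitrogen.

Among the compounds with values here, no measured step shows what such a swap does, so no change beyond the scatter is expected in this assay. The expected size is the estimated a number no higher from compound 2 to compound 4 (the limit leaves the size open). For compound 4 the estimate is 100000 nM, with an expected range of 30000 nM to 300000 nM.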

Compound 4, half-maximal inhibitory concentration: 39000 nM
Estimate against measurement, compound 4: 2.6-fold (0.41 log units) above, within the range that was stated.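

In this assay, 5-bromopyridin-3-yl in place of 2-fluorophenyl on a saturated chain carbon bound to an amide-type nitrogen gives an at least 2.5-fold lower number from compound 2 to compound 4 (0.40 log units; beyond the scatter). This shows that the group at this position can move a compound off the limit, and compound 4 is the only one of the four with a real number. The size of the step is only a minimum, because compound 2 rests on a limit shared by most of the set: the limit of > 100000 nM in this assay, at which 3 of the 4 values shown sit.

The change brings in a ring nitrogen and a bromine and removes a fluorine all at once, so the compounds shown cannot separate these parts. Going by these compounds, it remains open whether a plain pyridin-3-yl without the bromine, or a chlorine in place of the bromine, would give a similar result.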